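A few compounds are considered here, and "the series" means these few. Any claim that something is new, unique, unknown or untested is made for them only; others in the source may bear on it.

In a functional assay on RAW264.7 cells (Mus musculus), read by Griess assay, with stated times of 1 h and 24 h (on this read-out lower numbers stand for stronger inhibition and higher numbers for weaker inhibition), compound 1 (`CN1CCN(CCCCCOc2cccc(N3C(=O)S/C(=C\c4ccc(Oc5ccc(F)cc5)cc4)C3=O)c2)CC1`) gives > 10000 nM, a limit of the assay and not a number. Compound 2 (`CN1CCN(CCCCCOc2cccc(N3C(=O)S/C(=C\c4ccc(Oc5ccc(Cl)cc5)cc4)C3=O)c2)CC1`) gives > 10000 nM, likewise only a limit, and this is all that is known of where compound 2 stands. Next comes compound 3 (`CN1CCN(CCCCCOc2cccc(N3C(=O)S/C(=C\c4ccc(Oc5ccc([N+](=O)[O-])cc5)cc4)C3=O)c2)CC1`), with nitro in place of chloro on an aromatic carbon, para to a large group: nitro in place of chloro on an aromatic carbon. For the measured compounds named here, the only measured step bearing on this change is a step that the two limits leave unreadable from compound 1 to compound 2, chloro in place of fluoro on an aromatic carbon, and it has no readable size. The data therefore give no size or direction for a step in this assay, and the working expectation is no shift away from the limit of > 10000 nM in this assay, at which 2 of the 2 values shown sit. The estimated step is a step that the limit leaves unreadable from compound 2 to compound 3. Compound 3 is expected at about 15000 nM, with an estimated range of 4000 nM to 40000 nM.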

Compound 3, half-maximal inhibitory concentration: > 10000 nM
Compound 3: no number, only a limit; the forecaster's own chance of this, stated with the estimate: 80%; the middle value does not contradict the limit.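

No step can be read among compound 1, compound 2 and compound 3 in this assay, and each value is a limit and not a number: the limit of > 10000 nM in this assay, at which 3 of the 3 values shown sit.

The compounds shown leave open how the fluoro, chloro and nitro compounds compare in inhibition, and whether any change to the shared core would bring a readable value.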